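Benzyloxy for chlorophenyl on the exocyclic carbon

The compounds below may be only part of what the source reports. "The series", "measured", "known", "first", "only" and "open" are said of these compounds alone.

Compound 2 `Cc1ccc(CN2C(=O)S/C(=C\c3ccc(Cl)cc3)C2=O)cc1` gives 18.7% in a functional assay on the whole organism (plasma) with Mus musculus as the target, with a stated time of 15 days, at a dose of 10 mg/kg by the oral route; on this read-out higher numbers stand for a stronger effect at the one dose given and lower numbers for a weaker effect. Compound 1 `Cc1ccc(/C=C2\SC(=O)N(Cc3ccc(C)cc3)C2=O)cc1` gives 16.3% in this assay; the step of a number 2.4 percentage points higher from compound 1 to compound 2 (within the scatter) lies within the scatter, so the two numbers cannot be ordered. Compound 3 `Cc1ccc(CN2C(=O)S/C(=C\OCc3ccccc3)C2=O)cc1` is not yet measured; it differs from compound 2 by benzyloxy in place of 4-chlorophenyl on a double-bonded chain carbon bound to a double-bonded ring carbon. Among the measured compounds shown here, no measured step exchanges the whole aromatic group; the only known step, a number 2.4 percentage points higher from compound 1 to compound 2 (within the scatter), concerns a substituent on that ring and stayed within the scatter, so it bears only loosely here. The expected step is a number 3.7 percentage points lower from compound 2 to compound 3 (within the scatter), not beyond the scatter. Compound 3 is estimated at 15%, between 4% and 30%.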

Compound 3, a percentage reported as activity, at one dose (the size of the read-out at that dose, not a potency): 9.37%
Estimate against measurement, compound 3: 5.6 percentage points above; low and high end bracket the measured number.
By their numbers in this assay, from the lowest: compounds 3, 1 and 2 (each within the scatter of the next).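

Replacing the whole aromatic group at this place, and not only a substituent on it, still gives steps that stay inside the scatter: in this assay, benzyloxy in place of 4-chlorophenyl gives a number 9.3 percentage points lower from compound 2 to compound 3 (within the scatter), and benzyloxy in place of 4-methylphenyl gives a number 6.9 percentage points lower from compound 1 to compound 3 (within the scatter). The read-out therefore does not separate benzyloxy from either aromatic group on this chain carbon. Nothing available explains these numbers.

On these data alone, whether an amine or a carboxylic acid at this place would give a step beyond the scatter remains open. The same holds for a longer chain in place of benzyloxy.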